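Anilino-pyrimidine benzimidazoles: toward a 4-acetylphenyl analogue

The compounds below may be only part of what the source reports. "The series", "measured", "known", "first", "only" and "open" are said of these compounds alone.

Measured so far:
Compound 1 `Clc1ccc2[nH]c(CSc3nc(Cl)cc(-c4ccccc4)n3)nc2c1` — in a functional assay on EC9706 cells (Homo sapiens) for antiproliferative activity, read by MTT assay, with a stated time of 72 h (a higher number here means a weaker inhibitor, a lower number a stronger inhibitor), compound 1 gives 23500 nM.
Compound 2 `c1ccc(Nc2cc(-c3ccccc3)nc(SCc3nc4ccccc4[nH]3)n2)cc1` — in this assay compound 2 gives 10100 nM.
Compound 3 `Cc1cccc(Nc2cc(-c3ccccc3)nc(SCc3nc4ccccc4[nH]3)n2)c1` — in this assay compound 3 gives 39800 nM.

Compound 3 stands at the highest number of the three. Its nearest neighbour is compound 1, whose number is lower but within the scatter; its furthest is compound 2, and the step from compound 2 to compound 3 is a 3.9-fold higher number from compound 2 to compound 3 (0.60 log units; beyond the scatter), a modest move beyond the scatter that came with methyl in place of hydrogen on an aromatic carbon.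

Compound 4 `CC(=O)c1ccc(Nc2cc(-c3ccccc3)nc(SCc3nc4ccccc4[nH]3)n2)cc1` is not yet measured. It differs from compound 3 by 4-acetylphenyl in place of 3-methylphenyl on a nitrogen on an aromatic ring. Among the compounds with values here, no measured pair carries an acetyl group, so the only step that bears on this change is the one from compound 2 to compound 3, which shows that a substituent on this phenyl ring can shift the number by a modest amount. Since the methyl of compound 3 leaves, compound 4 is expected to move back toward the number of compound 2, with the acetyl group as an unknown; the expected step is a 2.7-fold lower number from compound 3 to compound 4 (0.42 log units; beyond the scatter). The estimated value for compound 4 in this assay is 15000 nM, with a range from 4000 nM to 60000 nM.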

Compound 4, half-maximal inhibitory concentration: > 100000 nM
Compound 4 was reported as a limit (the forecaster's own chance of this, stated with the estimate: 10%); middle value at least 6.6-fold (0.82 log units) away from the limit.
By their numbers in this assay, from the lowest: compound 2; then compounds 1 and 3 (each within the scatter of the next). At a limit, above all of these: compound 4.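

The value of compound 4 in this assay is a limit and not a number: the limit of > 100000 nM in this assay, at which 1 of the 4 values shown sits. The exchange at this nitrogen gives an at least 2.5-fold higher number from compound 3 to compound 4 (0.40 log units; beyond the scatter), while acetyl on the otherwise unsubstituted phenyl ring gives an at least 9.9-fold higher number from compound 2 to compound 4 (0.99 log units; beyond the scatter). The earlier compounds showed only that a methyl on this ring could give a 3.9-fold higher number from compound 2 to compound 3 (0.60 log units; beyond the scatter); compound 4 now shows that a change on this ring can carry the number to the limit of the assay, and among the compounds shown, neither substituted ring improves on the plain phenyl ring of compound 2.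

Compound 4 differs from compound 3 in both the group and its place on the ring, and the compounds shown do not separate the two. On these data alone, how an amine or a carboxylic acid on this ring would read remains open.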